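The source may hold more compounds than are shown below. What is called first, only, known or untested is meant among the compounds shown, and "the series" means these compounds.

Measured compounds:
- compound 1, `Cc1oc(-c2ccc(Cl)cc2)nc1CN1CCC(C(=O)NCCCN2C[C@H](C)C[C@H](C)C2)CC1`; in a physicochemical assay for permeability, using PAMPA (a lower number here means that the compound crosses the layer more slowly, a higher number that the compound crosses the layer faster), compound 1 sits at the assay limit, > 635 10^-6 cm/s, so only a limit and no number is known for it.
- compound 2, `Cc1ccccc1-c1nc(CN2CCC(C(=O)NCCN3C[C@H](C)C[C@H](C)C3)CC2)c(C)o1`; compound 2 gives 712 10^-6 cm/s.
- compound 3, `Cc1ccccc1-c1nc(CN2CCC(C(=O)N3CCN(CCN(C)C)CC3)CC2)c(C)o1`; compound 3 gives 14 10^-6 cm/s.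

Within the data shown here, the one measured step in this small set is a 51-fold lower number from compound 2 to compound 3 (1.71 log units; beyond the scatter), a change at the carbonyl carbon on the amide side of the shared core. It says nothing about the aryl group on the five-membered ring, which is where compound 4, `Cc1cccc(C)c1-c1nc(CN2CCC(C(=O)NCCCN3C[C@H](C)C[C@H](C)C3)CC2)c(C)o1`, differs from compound 1: 2,6-dimethylphenyl in place of 4-chlorophenyl on an aromatic carbon. Among the measured compounds shown here, no measured pair bears on that exchange, so no step beyond the scatter is expected from it. Compound 1 stands at the limit of > 635 10^-6 cm/s in this assay, at which 1 of the 3 values shown sits, and with compound 2 the same amide side already reaches a number of similar size. The expectation for compound 4 is a permeability close to that of compound 1, a step that the limit leaves unreadable from compound 1 to compound 4, with a fair chance that the assay again reports only a limit. Compound 4 is therefore estimated at 700 10^-6 cm/s, ranging from 400 10^-6 cm/s to 1200 10^-6 cm/s.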

Compound 4, apparent permeability: 254 10^-6 cm/s
Compound 4: the middle estimate sits 2.8-fold (0.44 log units) above what was measured, outside the stated range (below it).
By their numbers in this assay, from the lowest: compound 3; then compound 4; then compound 2.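

In this assay, the exchange of 4-chlorophenyl for 2,6-dimethylphenyl on an aromatic carbon of the five-membered aromatic ring gives an at least 2.5-fold lower number from compound 1 to compound 4 (0.39 log units; beyond the scatter). Among these compounds, this is the first step at this position, as the only earlier step lay at the carbonyl carbon, and it shows that the aryl group can shift the read-out beyond the scatter. The true size of the step stays unknown, and only its lower bound can be read, because compound 1 carries a limit and not a number: the limit of > 635 10^-6 cm/s in this assay, at which 1 of the 4 values shown sits.

Open, from the compounds shown here alone, is whether the step follows from the loss of the chlorine or from the two methyl groups, which a plain phenyl or a 4-methylphenyl group on the same amide side would help to separate. Also open, going by these compounds, is whether the same exchange gives a step of similar size with another amide side.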